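This account rests on a few compounds, and the source may have more. Where it says the series, first, only, none or still open, it means among the compounds named here.

Working notes on the series. The three measured compounds share one core and differ in the group attached to the saturated chain carbon bound to the aromatic nitrogen. Compound 1 `O=C(O)CCc1ccc(NCc2ccc(Cl)s2)cc1` carries a 5-chlorothiophen-2-yl there; in a functional assay on CHO cells for agonist activity at Free fatty acid receptor 1 (Homo sapiens), read by reporter gene assay (a lower number here means a smaller maximal response, a higher number a larger maximal response), compound 1 gives 143%. Compound 2 `O=C(O)CCc1ccc(NCc2cccc(F)c2)cc1` gives 120% in this assay, and compound 3 `COc1ccc(CNc2ccc(CCC(=O)O)cc2)cc1` gives 159%. Among these three numbers compound 1 stands second highest: compound 3 lies above it beyond the scatter, and compound 2 lies below it beyond the scatter.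

Compound 4 `O=C(O)CCc1ccc(NCc2ncc[nH]2)cc1` is not yet measured. It differs from compound 1 in one place: 1H-imidazol-2-yl in place of 5-chlorothiophen-2-yl on a saturated chain carbon bound to a nitrogen on an aromatic ring. For the measured compounds named here, the group that enters brings a hydrogen-bond donor that the leaving group lacks and has one heavy atom fewer; no measured pair covers such a change, so the step is judged from the spread seen so far. A step downward beyond the scatter is expected for this assay, of about the size a number 28 percentage points lower from compound 1 to compound 4 (beyond the scatter). For compound 4 the expected largest response is 115%, with a range from 85% to 145%.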

Compound 4, largest response reached (reported as percent of maximum), in percent of the reference or control that the assay uses: 4%
Beside the measured number, compound 4's estimate is 111 percentage points above it, outside the stated range (below it).
By their numbers in this assay, from the lowest: compound 4; then compound 2; then compound 1; then compound 3.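

At this position, in this assay, the swap of one five-membered aromatic ring for another gives a number 139 percentage points lower from compound 1 to compound 4 (beyond the scatter) and opens a gap wider than any among the printed values of compound 1, compound 2 and compound 3, so the earlier spread understated how much this group can matter. Both groups carry no net charge, so the loss comes with a shared ring size and charge; what differs by count is the added hydrogen-bond donor, the second ring hetero atom and the departure of sulfur and chlorine. Nothing on hand bears on the reason for the loss.

This single step cannot separate those differences from one another. A thiophen-2-yl without chlorine, or an imidazole carrying a methyl on its ring nitrogen, would help to tell which of them goes with the collapse in maximal response.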